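Swapping the group on the carbonyl carbon

This account rests on a few compounds, and the source may have more. Where it says the series, first, only, none or still open, it means among the compounds named here.

Compound 2 `CCn1c(C(=O)N(CCC#N)CCC#N)ccc1C(CC)(CC)c1ccc(OCCC(O)(CC)CC)c(C)c1` stands at > 50000 nM in a functional assay on PC-3 cells (Homo sapiens) for antiproliferative activity, read by MTT assay, with a stated time of 48 h (on this read-out higher numbers stand for weaker inhibition and lower numbers for stronger inhibition), which is a limit and not a number. Within the data shown here, compound 1 `CCn1c(C(=O)NCCN)ccc1C(CC)(CC)c1ccc(OCCC(O)(CC)CC)c(C)c1` gives 2420 nM, the only true number so far. Compound 3 `C=CCN(C)C(=O)c1ccc(C(CC)(CC)c2ccc(OCCC(O)(CC)CC)c(C)c2)n1CC` carries allyl(methyl)amino on the carbonyl carbon: a group of 5 heavy atoms (4 carbon, 1 nitrogen; no ring) in place of a group of 9 heavy atoms (6 carbon, 3 nitrogen; no ring), on a carbonyl carbon. Among the measured compounds shown here, the one measured step at this carbonyl carbon, an at least 20-fold higher number from compound 1 to compound 2 (1.31 log units; beyond the scatter), is large and ends at a limit, so it bounds the change only loosely. A step toward lower numbers is expected, with compound 3 remaining weaker than compound 1 at 2420 nM. The expected step is an at least 2.0-fold lower number from compound 2 to compound 3 (0.30 log units; that floor lies within the scatter). For compound 3 the estimated value is 25000 nM, within an expected range of 7000 nM to 80000 nM.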

Compound 3, half-maximal inhibitory concentration: 12800 nM
Beside the measured number, compound 3's estimate is 2.0-fold (0.29 log units) above it; the range from low to high includes it.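

Compound 3 gives this carbonyl carbon a second true number, whereas compound 2 holds only a limit: the limit of > 50000 nM in this assay, at which 1 of the 3 values shown sits. The change to allyl(methyl)amino is an at least 3.9-fold lower number from compound 2 to compound 3 (0.59 log units; beyond the scatter), a floor and not a size, while against (2-aminoethyl)amino the result is a 5.3-fold higher number from compound 1 to compound 3 (0.72 log units; beyond the scatter). Across these three groups the read-out at this position is therefore graded rather than all-or-none, with compound 1 still holding the lowest number.

Open, going by these compounds, is how a ring amine such as morpholine would read on this carbonyl carbon. Also open, on these data alone, is whether a longer chain ending in a primary amine, such as (3-aminopropyl)amino, would go below compound 1.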